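Furan for thiophene on the saturated ring carbon

The source may hold more compounds than are shown below. What is called first, only, known or untested is meant among the compounds shown, and "the series" means these compounds.

Measured compounds in a functional assay on HepG2 cells (Homo sapiens) for cytotoxicity, read by MTT assay, with a stated time of 48 h; on this read-out higher numbers stand for weaker inhibition and lower numbers for stronger inhibition:
compound 1, `COc1cc(-c2nnc3n2NC(c2ccco2)C(C(=O)c2ccccc2F)S3)cc(OC)c1OC`, gives > 100000 nM, which is a limit of the assay.
compound 2, `COc1cc(-c2nnc3n2NC(c2ccco2)C(C(=O)C2CC2)S3)cc(OC)c1OC`, gives > 100000 nM, which is a limit of the assay.
compound 3, `COc1ccc(C(=O)C2Sc3nnc(-c4cc(OC)c(OC)c(OC)c4)n3NC2c2cccs2)cc1`, gives 68000 nM.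

Within the data shown here, compound 3 stands as the only value in this assay that is a number; the remaining values sit at a limit, (the limit of > 100000 nM in this assay, at which 2 of the 3 values shown sit). Among the measured compounds shown here, the single measured step, a step that the two limits leave unreadable from compound 1 to compound 2, runs between limits and cannot be sized. Compound 4, `COc1ccc(C(=O)C2Sc3nnc(-c4cc(OC)c(OC)c(OC)c4)n3NC2c2ccco2)cc1`, differs from compound 3 by furan-2-yl in place of thiophen-2-yl on a saturated ring carbon. For the measured compounds named here, no measured step concerns this exchange, and the one step known does not bear on it. For compound 4 in this assay the expected step of a 1.1-fold higher number from compound 3 to compound 4 (0.04 log units; within the scatter) is therefore none beyond the scatter. Compound 4 is estimated at 75000 nM, between 30000 nM and 200000 nM, with a fair chance that only a limit is returned.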

Compound 4, half-maximal inhibitory concentration: > 100000 nM
Compound 4: only a limit was reported; the forecaster's own chance of this, stated with the estimate: 40%; at least 1.3-fold (0.12 log units) between middle value and limit.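

In this assay, furan-2-yl in place of thiophen-2-yl on the saturated ring carbon gives an at least 1.4-fold higher number from compound 3 to compound 4 (0.16 log units; that floor lies within the scatter), so the change has only a floor and no size beyond the scatter can be claimed. Compound 4 returns only a limit, as do both other furan-2-yl compounds, so thiophen-2-yl stands on the only compound with a number, and the steps among limits cannot be read: the limit of > 100000 nM in this assay, at which 3 of the 4 values shown sit.

On these data alone, the true size of this exchange stays open. So does the effect of a piperidine or a carboxylic acid on that saturated ring carbon.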